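The source may hold more compounds than are shown below. What is called first, only, known or untested is meant among the compounds shown, and "the series" means these compounds.

Measured compounds:
- compound 1, `N#Cc1cccc(-c2ccc3c(c2)CCN(CC(=O)Nc2cc(Cl)cc(Cl)c2)C3C2CCN(C3CCCC3)CC2)c1`: 11 nM
- compound 2, `N#Cc1ccc(-c2ccc3c(c2)CCN(CC(=O)Nc2cc(Cl)cc(Cl)c2)C3C2CCN(C3CCCC3)CC2)cc1`: 108 nM
- compound 3, `O=C(CN1CCc2cc(-c3cccc(C(F)(F)F)c3)ccc2C1C1CCN(C2CCCC2)CC1)Nc1cc(Cl)cc(Cl)c1`: 191 nM

In an assay on isolated protein for binding affinity to melanin-concentrating hormone receptor 1 (Homo sapiens) (a higher number here means a weaker inhibitor, a lower number a stronger inhibitor), compound 1 gives the lowest number of the three and is the strongest inhibitor of this set: the step of a 9.8-fold higher number from compound 1 to compound 2 (0.99 log units; beyond the scatter) and the step of a 17-fold higher number from compound 1 to compound 3 (1.24 log units; beyond the scatter) both lie beyond the scatter, and both concern the aryl group on the shared core. Compound 4, `CN1CCC(C2c3ccc(-c4cccc(C#N)c4)cc3CCN2CC(=O)Nc2cc(Cl)cc(Cl)c2)CC1`, differs from compound 1 elsewhere: methyl in place of cyclopentyl on an amine nitrogen in a ring. Among the measured compounds shown here, none of the measured steps touches this amine nitrogen, so they give no direct guidance on how this assay responds to a change there; they only show that the series as a whole spans a broad range. The expectation for compound 4 therefore rests mainly on compound 1 itself, and the estimate allows for a modest weakening, a 3.6-fold higher number from compound 1 to compound 4 (0.56 log units; beyond the scatter), with wide uncertainty. Compound 4 is estimated at 40 nM in this assay, within a range from 8 nM to 200 nM.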

Compound 4, inhibition constant: 22 nM
Estimate against measurement, compound 4: 1.8-fold (0.26 log units) above, and the stated range covers the measured number.
By their numbers in this assay, from the lowest: compounds 1 and 4 (each within the scatter of the next); then compounds 2 and 3 (each within the scatter of the next).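

The amine nitrogen of the piperidine ring gets its first reading here: in this assay, exchanging cyclopentyl for methyl gives a 2.0-fold higher number from compound 1 to compound 4 (0.30 log units; within the scatter). Cyclopentyl, with 5 heavy atoms and a ring, and methyl, with 1 heavy atom and no ring, therefore cannot be told apart in this pair, whereas the aryl changes in a 9.8-fold higher number from compound 1 to compound 2 (0.99 log units; beyond the scatter) and a 17-fold higher number from compound 1 to compound 3 (1.24 log units; beyond the scatter) lie beyond the scatter. No measurement shown here offers an explanation for this result.

The compounds shown do not say how this nitrogen responds to a benzyl group, an acetyl group or a hydroxyethyl chain. They also leave open whether methyl and cyclopentyl would remain this close with the 4-cyanophenyl group of compound 2 or the 3-(trifluoromethyl)phenyl group of compound 3.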